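Replacing the amine chain of compound 3 with an amino acid

A few compounds are considered here, and "the series" means these few. Any claim that something is new, unique, unknown or untested is made for them only; others in the source may bear on it.

The measured compounds are compound 1 `CCN(CC)CCNC(=O)c1ccc(C(CC)(CC)c2ccc(OCC(=O)C(C)(C)C)c(C)c2)n1CC` with 620 nM, compound 2 `CCn1c(C(=O)NCCCN(C)C)ccc1C(CC)(CC)c1ccc(OCC(=O)C(C)(C)C)c(C)c1` with 960 nM and compound 3 `CCN(CC)CCCNC(=O)c1ccc(C(CC)(CC)c2ccc(OCC(O)C(C)(C)C)c(C)c2)n1CC` with 1100 nM, all in a functional assay on HepG2 cells (Homo sapiens), read by MTT assay, with a stated time of 48 h; on this read-out lower numbers stand for stronger inhibition and higher numbers for weaker inhibition.

Compound 3 gives the highest of the three numbers in this assay, but its distance to compound 2 and to compound 1 lies within the scatter, so the three cannot be set apart. Going by the values given here, the one step measured between close neighbours, a 1.5-fold higher number from compound 1 to compound 2 (0.19 log units; within the scatter), concerns a change on the chain two bonds from the amide-type nitrogen and also stays within the scatter.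

Compound 4 `CC[C@@H](C)[C@H](NC(=O)c1ccc(C(CC)(CC)c2ccc(OCC(O)C(C)(C)C)c(C)c2)n1CC)C(=O)O` differs from compound 3 in the group carried by the amide-type nitrogen: 1-carboxy-2-methylbutyl in place of 3-(diethylamino)propyl on an amide-type nitrogen. Among the compounds with values here, no measured step bears on this change. The step from compound 1 to compound 2 exchanged one amine for another on the chain, whereas here the whole 3-(diethylamino)propyl chain is exchanged for 1-carboxy-2-methylbutyl, which brings a hydrogen-bond donor and two defined stereocentres and removes the nitrogen. Within the data shown here, the expectation therefore rests on no measured precedent, and it is estimated that compound 4 shows a weaker result in this assay, with a step of a 2.3-fold higher number from compound 3 to compound 4 (0.36 log units; beyond the scatter) and a wide range. Compound 4 is expected to give 2500 nM, within 800 nM and 8000 nM.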

Compound 4, half-maximal inhibitory concentration: 127 nM
The estimate for compound 4 lay 20-fold (1.29 log units) above the measured number; the whole stated range lies above it.
By their numbers in this assay, from the lowest: compound 4; then compounds 1, 2 and 3 (each within the scatter of the next).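

The position on the amide-type nitrogen had shown nothing beyond the scatter while only the amine on the chain was exchanged (a 1.5-fold higher number from compound 1 to compound 2 (0.19 log units; within the scatter)), but it responds once the whole group is replaced: in this assay there is an 8.7-fold lower number from compound 3 to compound 4 (0.94 log units; beyond the scatter), a step beyond the scatter. For this pair, therefore, a low number does not depend on keeping the 3-(diethylamino)propyl chain, since 1-carboxy-2-methylbutyl carries no nitrogen and still gives the lower number, and the heavy-atom count of the group stays the same at 8 across the exchange. No measurement shown gives a reason for this step.

The compounds shown do not separate the contribution of the carboxylic acid from that of the branched carbon chain or the 2 defined stereocentres, and a methyl ester, a plain 2-methylbutyl group or the opposite stereoisomer at either centre would bear on that. On these data alone, it also stays open whether 1-carboxy-2-methylbutyl gives a similar step on the ketone carried by compound 1 and compound 2, as compound 4 holds the alcohol of compound 3.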